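Toward compound 3: a dichlorophenyl change

The compounds below may be only part of what the source reports. "The series", "measured", "known", "first", "only" and "open" are said of these compounds alone.

Within the data shown here, in a functional assay on A549 cells (Homo sapiens) for antiproliferative activity, read by MTT assay, with a stated time of 72 h (on this read-out lower numbers stand for stronger inhibition and higher numbers for weaker inhibition), compound 2 (`O=C(N/N=C/c1ccccc1)Nc1ccc(Oc2ccnc3[nH]ccc23)cc1`) gives 17200 nM as the higher of the two numbers so far, while compound 1 (`O=C(N/N=C/c1ccccc1)Nc1ccc(Oc2ccnc3[nH]ccc23)c(F)c1`) gives 2500 nM as the lower. Compound 3 (`O=C(N/N=C/c1cccc(Cl)c1Cl)Nc1ccc(Oc2ccnc3[nH]ccc23)cc1`) carries 2,3-dichlorophenyl in place of phenyl on a carbon with a double bond to nitrogen. Among the measured compounds shown here, the only measured step (a 6.9-fold higher number from compound 1 to compound 2 (0.84 log units; beyond the scatter)) puts hydrogen in place of fluoro on an aromatic carbon. It is a different change and bears only loosely. A step of similar modest size toward lower numbers is expected (a 2.9-fold lower number from compound 2 to compound 3 (0.46 log units; beyond the scatter)) in this assay as well. For compound 3 the estimated value is 6000 nM (expected range 1500 nM to 20000 nM).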

Compound 3, half-maximal inhibitory concentration: "not active" (no number reported)
For compound 3 the study gives words and no number; the estimate stays without a comparison.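

Among these compounds, compound 3 is reported only in words, so no step from compound 2 to compound 3 can be read. No measurement shown bears on this result. The compounds shown leave open how 2,3-dichlorophenyl would read on the core of compound 1.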